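The source may report more compounds than this note shows. Statements on the series, on what has been measured and on what is new or still open speak of the compounds shown alone.

In a functional assay on B16-F10 cells (Mus musculus) for cytotoxicity, read by CCK-8 assay, with a stated time of 48 h (on this read-out higher numbers stand for weaker inhibition and lower numbers for stronger inhibition), compound 1 `NS(=O)(=O)c1ccc(/N=C/c2c(Cl)c3ccccc3oc2=O)cc1` gives 300 nM, and compound 2 `O=c1oc2ccccc2c(Cl)c1/C=N/c1ccc(S(=O)(=O)Nc2nccs2)cc1`, which carries a 1,3-thiazol-2-yl on the sulfonamide nitrogen, gives 300 nM; the step of no change at the digits printed from compound 1 to compound 2 (within the scatter) is therefore a flat one. Compound 3 `Cc1ccc2oc(=O)c(/C=N/c3ccc(S(N)(=O)=O)cc3)c(Cl)c2c1` gives 360 nM in this assay, and the step of a 1.2-fold higher number from compound 1 to compound 3 (0.08 log units; within the scatter) shows that its number sits with those of compound 1 and compound 2 rather than apart from them; the three numbers are, within the scatter, one number.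

Compound 4 `Cc1ccc2oc(=O)c(/C=N/c3ccc(S(=O)(=O)Nc4nccs4)cc3)c(Cl)c2c1` differs from compound 3 in one place: 1,3-thiazol-2-yl in place of hydrogen on a sulfonamide nitrogen. This is the same change that separates compound 1 from compound 2, and there it left the number unchanged within the scatter. The methyl that distinguishes compound 3 from compound 1 also moved the number only within the scatter. Among the compounds with values here, there is no measured pair in which this change on the methylated core has been tested, so the expectation rests on the single step from compound 1 to compound 2 alone.

On that basis the step of no change at the digits printed from compound 3 to compound 4 (within the scatter) is expected to fall within the scatter. Compound 4 is therefore estimated to give 360 nM in this assay, with a range from 200 nM to 650 nM.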

Compound 4, half-maximal inhibitory concentration: 280 nM
Beside the measured number, compound 4's estimate is 1.3-fold (0.11 log units) above it; measured number inside the range.
By their numbers in this assay, from the lowest: compounds 4, 1, 2 and 3 (each within the scatter of the next).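

In this assay the 1,3-thiazol-2-yl on the sulfonamide nitrogen, until now read only on the core of compound 1, gives a 1.3-fold lower number from compound 3 to compound 4 (0.11 log units; within the scatter) on the methylated core, so the flat result is not confined to a single core. The change therefore reads the same in both settings, with the sulfonamide nitrogen tolerating this five-membered aromatic ring in place of hydrogen without a step beyond the scatter: the same change on two cores in this assay, no change at the digits printed (within the scatter) from compound 1 to compound 2 and a 1.3-fold lower number (0.11 log units; within the scatter) from compound 3 to compound 4, 1.3-fold (0.11 log units) apart, within the scatter of two such steps. The methyl in place of hydrogen on an aromatic carbon can now also be read with the 1,3-thiazol-2-yl present, where it gives a 1.1-fold lower number from compound 2 to compound 4 (0.03 log units; within the scatter) and again leaves the number within the scatter: the same change on two cores in this assay, a 1.2-fold higher number (0.08 log units; within the scatter) from compound 1 to compound 3 and a 1.1-fold lower number (0.03 log units; within the scatter) from compound 2 to compound 4, 1.3-fold (0.11 log units) apart, within the scatter of two such steps.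

No step among these four compounds exceeds the scatter, so they do not show how far either place can be changed before the number moves. It remains open whether an acetyl or a pyridin-2-yl on the sulfonamide nitrogen, or a methoxy or a carboxylic acid on the aromatic carbon that carries the methyl, would stay as flat as the groups shown.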